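The compounds below may be only part of what the source reports. "The series", "measured", "known", "first", "only" and "open" are said of these compounds alone.

Compound 1 `NS(=O)(=O)c1ccc(COc2ccc(CNC(=O)[C@@H]3CCC(=O)N3Cc3ccccc3)cc2)cc1` is the parent of the series. In an assay on HEK293 cells for inhibition of Ataxin-2 (Mus musculus), read by fluorescence and Amplex Red (on this read-out higher numbers stand for weaker inhibition and lower numbers for stronger inhibition), compound 1 gives > 5000 nM, which is a limit of the assay and not a number. Compound 2 `NS(=O)(=O)c1ccc(COc2ccc(CNC(=O)[C@@H]3CCC(=O)N3Cc3ccc(F)cc3)cc2)cc1` differs from it only on the benzyl ring; in this assay compound 2 gives > 5000 nM, again a limit rather than a number. The step that the two limits leave unreadable from compound 1 to compound 2 cannot be read because of the limit of > 5000 nM in this assay, at which 2 of the 3 values shown sit. Among the compounds with values here, compound 3 `CC1(C)OB(c2ccc(COc3ccc(CNC(=O)[C@@H]4CCC(=O)N4Cc4ccccc4)cc3)cc2)OC1(C)C` differs from compound 1 at the outer ring; in this assay compound 3 gives 50 nM, the only actual number among the three values, and the step of an at least 100-fold lower number from compound 1 to compound 3 (2.00 log units; beyond the scatter) is large and beyond the scatter. Compound 4 `CC1(C)OB(c2ccc(COc3ccc(CNC(=O)[C@@H]4CCC(=O)N4Cc4ccc(F)cc4)cc3)cc2)OC1(C)C` is not yet measured. Against compound 3 the change is fluoro in place of hydrogen on an aromatic carbon. Within the data shown here, the only measured step of the same kind, a step that the two limits leave unreadable from compound 1 to compound 2, gives no size, since both of its ends are limits. Among the measured compounds shown here, no measured step therefore points to a change beyond the scatter for this substitution, and the step of no change at the digits printed from compound 3 to compound 4 (within the scatter) is estimated to lie within the scatter, in no particular direction. Compound 4 is expected to give 50 nM, with a range from 20 nM to 150 nM.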

Compound 4, half-maximal inhibitory concentration: 120 nM
Beside the measured number, compound 4's estimate is 2.4-fold (0.38 log units) below it, within the range that was stated.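

In this assay, fluoro in place of hydrogen on this aromatic carbon, taking benzyl to 4-fluorobenzyl, now has a readable size on the boron-bearing core: a 2.4-fold higher number from compound 3 to compound 4 (0.38 log units; beyond the scatter), a modest loss of inhibition, whereas the same change on the sulfonamide-bearing core cannot be read, since both of its values are limits. The 4-fluorobenzyl group does not remove the large advantage of the boron-containing five-membered ring group over the sulfonamide group, as an at least 41-fold lower number from compound 2 to compound 4 (1.61 log units; beyond the scatter) shows. The exchange of the outer group thus holds on both benzyl variants, while a comparison of its size on the two stays closed: the same change on two cores in this assay, an at least 100-fold lower number (2.00 log units; beyond the scatter) from compound 1 to compound 3 and an at least 41-fold lower number (1.61 log units; beyond the scatter) from compound 2 to compound 4; the limit leaves it open whether they differ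

Fluoro is the only replacement for hydrogen shown at this place, so the compounds leave open how chloro, methoxy or an amine would read there, and whether the modest step carries over to other positions on the benzyl ring. They also leave open which part of the boron-containing group goes with the lower numbers, a question that a free boronic acid or a carboxylic acid at the same aromatic carbon would address.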